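Does a Methyl Group Change Cytotoxicity on a Second Core?

The source may hold more compounds than are shown below. What is called first, only, known or untested is meant among the compounds shown, and "the series" means these compounds.

Of the compounds shown here, three have been measured in a functional assay on J774 cells (Mus musculus) for cytotoxicity, read by resazurin assay; a lower number here means a stronger inhibitor, a higher number a weaker inhibitor. Compound 1 `OCCCCCC(O)c1ccc(-c2ccccc2)cc1` gives 22000 nM. Compound 3 `Cc1ccccc1-c1ccc(C(O)CCCCCO)cc1`, which carries a methyl in place of hydrogen on an aromatic carbon, ortho to a large group, gives 24000 nM; this is the difference (methyl in place of hydrogen on an aromatic carbon), and the step of a 1.1-fold higher number from compound 1 to compound 3 (0.04 log units; within the scatter) is too small to count as a real change. Compound 2 `OCCCCCC(O)c1ccc(-c2ccc(F)cc2F)cc1` gives 8000 nM, the lowest number of the three, and its gaps to compound 1 and compound 3 lie beyond the usual scatter. How the core of compound 2 differs from the core of compound 1 is not broken down here.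

Compound 4 `Cc1cc(C(O)CCCCCO)ccc1-c1ccc(F)cc1F` has not yet been measured. Among the measured compounds shown here, it differs from compound 2 by methyl in place of hydrogen on an aromatic carbon, and the place is not identical to the one in compound 3: there the methyl sat ortho to a large group, here it sits ortho to a group of 8 heavy atoms and meta to a group of 8 heavy atoms. It is the same kind of change, made on a different core.

The expectation for compound 4 rests on one earlier step: because a 1.1-fold higher number from compound 1 to compound 3 (0.04 log units; within the scatter) stayed within the scatter, the step of a 1.1-fold higher number from compound 2 to compound 4 (0.05 log units; within the scatter) is also expected to stay small. Compound 4 is therefore estimated at 9000 nM in this assay, with a plausible range from 4000 nM to 20000 nM.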

Compound 4, half-maximal inhibitory concentration: 8000 nM
Estimate against measurement, compound 4: 1.1-fold (0.05 log units) above, within the range that was stated.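

In this assay, placing a methyl in place of hydrogen on an aromatic carbon of the second core gives no change at the digits printed from compound 2 to compound 4 (within the scatter), so here, as on the first core, the change produces no step larger than the ordinary spread of repeated measurements. Set side by side, the two steps do not differ, which means that in this small set the result for the methyl on one core carried over to the other: the same change on two cores in this assay, a 1.1-fold higher number (0.04 log units; within the scatter) from compound 1 to compound 3 and no change at the digits printed (within the scatter) from compound 2 to compound 4, 1.1-fold (0.04 log units) apart, within the scatter of two such steps. Among the compounds shown here, this rests on only two pairs of compounds in a single cell assay, with the methyl not in an identical place on the two cores, so it does not show that a methyl would leave the number unmoved on any other core or at any other ring position, and it gives no reason why the number holds still.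

The compounds shown leave open whether a larger group on the same aromatic carbon, such as an ethyl or a methoxy, would behave as the methyl does. They also leave open whether an amine or a carboxylic acid at that place, or a longer chain in place of the one carrying the two hydroxyl groups, would shift the number on either core.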